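A few compounds are considered here, and "the series" means these few. Any claim that something is new, unique, unknown or untested is made for them only; others in the source may bear on it.

Measured so far:
- compound 1 `COc1cc(NC(C)CCCNC(=O)NNC(=O)Nc2cccc(C(F)(F)F)c2)c2ncccc2c1`: 4000 nM
- compound 2 `COc1cc(NC(C)CCCNC(=O)NNC(=O)Nc2cccc(Cl)c2)c2ncccc2c1`: 27000 nM

In a functional assay on L1210 cells (Mus musculus) for inhibition, read by MTT assay, with a stated time of 72 h (a higher number here means a weaker inhibitor, a lower number a stronger inhibitor), compound 2 gives 27000 nM, the higher of the two numbers and so the weaker inhibitor of the pair. The next compound is compound 3 `COc1cc(NC(C)CCCNC(=O)NNC(=O)Nc2ccc(O)cc2)c2ncccc2c1`, with 4-hydroxyphenyl in place of 3-chlorophenyl on an amide-type nitrogen.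

For the measured compounds named here, only one measured step bears on this change: a 6.8-fold higher number from compound 1 to compound 2 (0.83 log units; beyond the scatter), a modest step beyond the scatter. It shows that a change on this aryl group can move the number, but it covers no hydroxyl group and no change of ring position, so it gives only a weak guide to direction.

The expected step is a 1.3-fold higher number from compound 2 to compound 3 (0.11 log units; within the scatter), not beyond the scatter, with the range leaning towards higher numbers. For compound 3 the estimate is 35000 nM, with an expected range of 12000 nM to 100000 nM.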

Compound 3, half-maximal inhibitory concentration: 95000 nM
Beside the measured number, compound 3's estimate is 2.7-fold (0.43 log units) below it, and the stated range covers the measured number.
By their numbers in this assay, from the lowest: compound 1; then compound 2; then compound 3.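

In this assay, 4-hydroxyphenyl on this amide-type nitrogen gives a 3.5-fold higher number from compound 2 to compound 3 (0.55 log units; beyond the scatter) and a 24-fold higher number from compound 1 to compound 3 (1.38 log units; beyond the scatter), which makes compound 3 the weakest inhibitor of the three. The aryl group at this place therefore moves the number over a wider span than the swap of trifluoromethyl for chloro alone showed, and the one hydroxyl-bearing ring shown sits at the weak end. No measurement shown here accounts for this loss.

The change from 3-chlorophenyl to 4-hydroxyphenyl alters both the group and its place on the ring, so 3-hydroxyphenyl and 4-chlorophenyl would be needed to split it into two single steps. From the compounds shown here alone, whether an amine or a carboxylic acid on this ring would follow the hydroxyl group also remains open.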